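The compounds below may be only part of what the source reports. "The series", "measured", "known", "first", "only" and "open" are said of these compounds alone.

Compound 1 `CC(C)Oc1cc(Oc2ccc(S(C)(=O)=O)cc2)cc(-c2nccc(=O)[nH]2)c1`: 25000 nM. Compound 2 `Cc1cnc(-c2cc(Oc3ccc(S(C)(=O)=O)cc3)cc(OC(C)C)c2)[nH]c1=O`: 1900 nM. Compound 3 `CC(C)Oc1cc(Oc2cnc(C(=O)N(C)C)nc2)cc(-c2nccc(=O)[nH]2)c1`: 332000 nM.

All three were measured in a physicochemical assay for solubility, in phosphate buffer, measured as kinetic solubility, with a stated time of 24 h, at pH 6.5; on this read-out higher numbers stand for higher solubility and lower numbers for lower solubility. Compound 2 differs from compound 1 in one place, (methyl in place of hydrogen on an aromatic carbon), and in this assay that change made a step of a 13-fold lower number from compound 1 to compound 2 (1.12 log units; beyond the scatter). Compound 4 `Cc1cnc(-c2cc(Oc3cnc(C(=O)N(C)C)nc3)cc(OC(C)C)c2)[nH]c1=O` has not yet been measured. It stands to compound 3 as compound 2 stands to compound 1: the change is methyl in place of hydrogen on an aromatic carbon, and the place is described in the same words, so it is the same change. How the core of compound 3 differs from the core of compound 1 is not broken down here. Among the measured compounds shown here, because the only earlier example of this change gave a 13-fold lower number from compound 1 to compound 2 (1.12 log units; beyond the scatter), a step of similar size is expected here, a 13-fold lower number from compound 3 to compound 4 (1.12 log units; beyond the scatter), resting on that single example. Compound 4 is therefore estimated at 25000 nM in this assay, between 8000 nM and 80000 nM.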

Compound 4, solubility: 218000 nM
For compound 4 the middle estimate is 8.7-fold (0.94 log units) below the measured one; the measured number lies above the stated range.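

In this assay, methyl in place of hydrogen on an aromatic carbon gave a 13-fold lower number from compound 1 to compound 2 (1.12 log units; beyond the scatter), whereas the same change on the core of compound 3 gave a 1.5-fold lower number from compound 3 to compound 4 (0.18 log units; within the scatter). The size of the step therefore did not carry over from one core to the other, although two pairs show only that it can depend on the core, not how it would behave on any further core. Nothing available explains why the two steps differ.

The compounds shown leave open what an ethyl group, an amine or a carboxylic acid on that same carbon would do on either core.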